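A few compounds are considered here, and "the series" means these few. Any claim that something is new, unique, unknown or untested is made for them only; others in the source may bear on it.

Compound 1, `Cc1ccc(S(=O)(=O)/C(=C/c2sccc2C)C(=O)c2ccc(Br)cc2)cc1`, gives 25000 nM in a functional assay on DU-145 cells (Homo sapiens) for inhibition, read by trypan blue exclusion, with a stated time of 96 h; a lower number here means a stronger inhibitor of growth, a higher number a weaker inhibitor of growth.
Compound 2, `Cc1ccc(S(=O)(=O)/C(=C/c2sccc2C)C(=O)c2ccc(Cl)cc2)cc1`, gives 10000 nM in this assay.
Compound 3, `Cc1ccc(CS(=O)(=O)/C(=C/c2sccc2C)C(=O)c2ccc(Cl)cc2)cc1`, gives 25000 nM in this assay.

Compound 2 has the lowest number of the three in this assay, and both of its neighbours sit beyond the scatter from it: a 2.5-fold lower number from compound 1 to compound 2 (0.40 log units; beyond the scatter), and a 2.5-fold higher number from compound 2 to compound 3 (0.40 log units; beyond the scatter). Compound 4, `Cc1ccc(S(=O)(=O)/C(=C/c2ccc(N(C)C)cc2)C(=O)c2ccc(Cl)cc2)cc1`, has not yet been measured. It differs from compound 2 in one place: 4-(dimethylamino)phenyl in place of 3-methylthiophen-2-yl on a double-bonded chain carbon bound to a double-bonded chain carbon.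

Neither measured step bears on this change. The step from compound 1 to compound 2 touches the halogen on the aromatic carbon, and the step from compound 2 to compound 3 touches the group on the sulfonyl sulfur; both are modest in size. Nothing measured here replaces the 3-methylthiophen-2-yl group, so the direction of the step in this assay is not known from these data. The best available guide is that the two single changes seen so far moved the number only modestly, so the expected change in this assay for compound 4 is no change at the digits printed from compound 2 to compound 4 (within the scatter), with a wide range. Compound 4 is therefore expected to give about 10000 nM, between 2500 nM and 40000 nM.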

Compound 4, concentration for 50% growth inhibition: > 100000 nM
Compound 4 ended at the assay's limit; the forecaster's own chance of this, stated with the estimate: 10%; at least 10-fold (1.00 log units) between middle value and limit.
By their numbers in this assay, from the lowest: compound 2; then compounds 1 and 3 (each within the scatter of the next). At a limit, above all of these: compound 4.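

Within the data shown here, the group on the double-bonded chain carbon bound to a double-bonded chain carbon turns out to matter for growth inhibition in this assay, which the earlier compounds could not show, since they all carry 3-methylthiophen-2-yl there. Placing 4-(dimethylamino)phenyl at this position in place of 3-methylthiophen-2-yl gives an at least 10-fold higher number from compound 2 to compound 4 (1.00 log units; beyond the scatter), a larger shift than the modest ones seen on changing the halogen or the group on the sulfonyl sulfur. Compound 4 gives > 100000 nM, which is a limit of the assay and not a number, so the full size of this step stays unknown: the limit of > 100000 nM in this assay, at which 1 of the 4 values shown sits.

This one change swaps a five-membered sulfur-containing ring for a six-membered carbon ring and also brings in a dimethylamino group, and the compounds shown cannot say which of these parts goes with the higher number. A plain phenyl group or a thiophen-2-yl group without the methyl at this position would help to separate these parts, and an amine other than dimethylamino would show whether the nitrogen group itself matters.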